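Shared core series: the step from compound 2 to compound 4

A few compounds are considered here, and "the series" means these few. Any claim that something is new, unique, unknown or untested is made for them only; others in the source may bear on it.

The shared core is the same throughout; what varies is the aromatic ring on the double-bonded chain. Compound 2 `COc1ccc(C(=O)/C=C/c2cccc([N+](=O)[O-])c2)c2c1C=CC(C)(C)O2` is the reference for this step. In a functional assay on K562 cells (Homo sapiens) for antiproliferative activity, read by MTT assay, with a stated time of 24 h (a higher number here means a weaker inhibitor, a lower number a stronger inhibitor), compound 2 gives 5870 nM, the lowest of the two numbers recorded in the set. Its nearest neighbour is compound 3 `COc1ccc(C(=O)/C=C/c2cccc(C(F)(F)F)c2)c2c1C=CC(C)(C)O2`; in this assay compound 3 gives 7850 nM. Among the compounds with values here, the only measured step, a 1.3-fold higher number from compound 2 to compound 3 (0.13 log units; within the scatter), replaces nitro with trifluoromethyl on an aromatic carbon and stays within the scatter. Compound 1 `COc1ccc(C(=O)/C=C/c2cc(OC)c(OC)c(OC)c2)c2c1C=CC(C)(C)O2` returns only a limit in this assay, > 10000 nM, so it is a limit and not a number (the limit of > 10000 nM in this assay, at which 1 of the 3 values shown sits).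

Compound 4 `COc1ccc(C(=O)/C=C/c2ccccc2Cl)c2c1C=CC(C)(C)O2` is not yet measured. From compound 2 the change is 2-chlorophenyl in place of 3-nitrophenyl on a double-bonded chain carbon bound to a double-bonded chain carbon. Within the data shown here, no measured step covers a change of this kind, and the single step that exists, between two substituents on the same ring position, did not move beyond the scatter. With the whole set lying high in this assay, the expectation for compound 4 is no step beyond the scatter, in either direction. The expected step is a 1.2-fold higher number from compound 2 to compound 4 (0.08 log units; within the scatter). Compound 4 is therefore estimated at 7000 nM, within a range from 2500 nM to 20000 nM.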

Compound 4, half-maximal inhibitory concentration: > 10000 nM
Compound 4: a limit, no number; the forecaster's own chance of this, stated with the estimate: 30%; middle value at least 1.4-fold (0.15 log units) away from the limit.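

Within the data shown here, replacing 3-nitrophenyl with 2-chlorophenyl on a double-bonded chain carbon bound to a double-bonded chain carbon gives an at least 1.7-fold higher number from compound 2 to compound 4 (0.23 log units; that floor lies within the scatter), and this is the first reading at this place for a change that alters both the substituent and the name of the ring group. Going by these compounds, because only a floor is printed for this step, it cannot show whether the change truly moves the value beyond the scatter, and its full size stays unknown. The limit in this assay now holds a second compound of the series, so the set gains another entry that can be placed but not ranked: the limit of > 10000 nM in this assay, at which 2 of the 4 values shown sit.

The compounds shown leave open whether the chlorine itself or its place on the ring governs the reading, as this single step changes both at once. Also open, on these data alone, is how an amine or a carboxylic acid on this aromatic ring would read in this assay, and whether any such group would give a number well clear of the limit.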